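Trifluoromethyl in place of a fluorinated sulfur group

The compounds below may be only part of what the source reports. "The series", "measured", "known", "first", "only" and "open" are said of these compounds alone.

In a functional assay on DU-145 cells (Homo sapiens) for antiproliferative activity, read by propidium iodide staining, with a stated time of 96 h (a higher number here means a weaker inhibitor, a lower number a stronger inhibitor), compound 1 (`CC(O)(CSc1cccc(C(F)(F)F)c1)C(=O)Nc1cccc(S(F)(F)(F)(F)F)c1`) gives 19100 nM and compound 2 (`CC(O)(CS(=O)(=O)c1cccc(S(F)(F)(F)(F)F)c1)C(=O)Nc1cccc(S(F)(F)(F)(F)F)c1`) gives 29400 nM. These two values lie within the scatter of each other. Compound 3 (`CC(O)(CS(=O)(=O)c1cccc(C(F)(F)F)c1)C(=O)Nc1cccc(S(F)(F)(F)(F)F)c1`) differs from compound 2 in one place, on an aromatic carbon: a group of 4 heavy atoms (1 carbon, 3 fluorine; no ring) in place of a group of 6 heavy atoms (5 fluorine, 1 sulfur; no ring), on an aromatic carbon. Trifluoromethyl enters there, and a group of 6 heavy atoms (5 fluorine, 1 sulfur) leaves. Going by the values given here, no measured pair isolates this change, and no step beyond the scatter is expected in this assay. The estimated step of a 1.2-fold lower number from compound 2 to compound 3 (0.09 log units; within the scatter) is expected to stay within the scatter. Compound 3 is expected at 24000 nM, with an estimated range from 10000 nM to 55000 nM.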

Compound 3, half-maximal inhibitory concentration: 37300 nM
For compound 3 the middle estimate is 1.6-fold (0.19 log units) below the measured one, within the range that was stated.
By their numbers in this assay, from the lowest: compounds 1, 2 and 3 (each within the scatter of the next).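

Going by these compounds alone, at this aromatic carbon, meta to a large group, the exchange of the group of 5 fluorine and 1 sulfur for trifluoromethyl gives the first one-place step: a 1.3-fold higher number from compound 2 to compound 3 (0.10 log units; within the scatter) in this assay. At this position, the two groups cannot be told apart in this read-out. No available data bear on why.

Still open, on these data alone, is whether a group of another kind here, such as an amine or a carboxylic acid, would give a step beyond the scatter. Also open, as far as these compounds go, is whether replacing the same group on the amide side would do so.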